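This account rests on a few compounds, and the source may have more. Where it says the series, first, only, none or still open, it means among the compounds named here.

Compound 2 `O=c1[nH]c(=O)n(COC(CO)CO)cc1[N+](=O)[O-]` carries a nitro group on an aromatic carbon of the shared core. In a functional assay on Vero cells (Chlorocebus sabaeus) for cytotoxicity (on this read-out lower numbers stand for higher toxicity in this test and higher numbers for lower toxicity in this test), compound 2 gives > 383000 nM, which is a limit of the assay and not a number. Its nearest measured neighbour is compound 1 `O=c1ccn(COC(CO)CO)c(=O)[nH]1`, in which that aromatic carbon bears a hydrogen instead. In this assay compound 1 gives > 462000 nM, again a limit rather than a number. The step that the two limits leave unreadable from compound 1 to compound 2 therefore cannot be read, as the limit of > 383000 nM in this assay, at which 1 of the 2 values shown sits, and the limit of > 462000 nM in this assay, at which 1 of the 2 values shown sits, both mark only the edge of what the test can detect. Compound 3 `Nc1cn(COC(CO)CO)c(=O)[nH]c1=O` differs from compound 2 by amino in place of nitro on an aromatic carbon. For the measured compounds named here, no measured step bears on this exchange, since the only step recorded, from hydrogen to nitro, has no readable size. With both measured compounds sitting at a limit, the step that the limit leaves unreadable from compound 2 to compound 3 is expected to be none beyond the scatter. For compound 3 in this assay the estimate is 400000 nM, within a range from 100000 nM to 1000000 nM, and most likely it will once more be reported only as a limit.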

Compound 3, half-maximal cytotoxic concentration: > 432000 nM
Compound 3 was reported as a limit; the forecaster's own chance of this, stated with the estimate: 80%; middle value at least 1.0-fold (0.03 log units) away from the limit.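

Compound 3, like compound 1 and compound 2, is reported in this assay only as a limit and not as a number, so no step among these three compounds can be read. The compounds shown leave open at what concentration any of them harms these cells, and whether hydrogen, nitro or amino on that aromatic carbon makes any difference.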